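Pendant phenyl swap: methyl to fluoro, two core variants

The compounds below may be only part of what the source reports. "The series", "measured", "known", "first", "only" and "open" are said of these compounds alone.

Working notes on a small set of aryl sulfonamides. The set holds compound 1 `O=C1COc2ccc(-c3cnc(Cl)c(NS(=O)(=O)c4ccc(F)cc4)c3)cc2N1c1ccc(F)cc1`, compound 2 `Cc1ccc(N2C(=O)COc3ccc(-c4cnc(Cl)c(NS(=O)(=O)c5ccc(F)cc5)c4)cc32)cc1`, compound 3 `Cc1ccc(N2C(=O)COc3ccc(-c4cccc(NS(=O)(=O)c5ccc(F)cc5)c4)cc32)cc1` and the not yet measured compound 4 `O=C1COc2ccc(-c3cccc(NS(=O)(=O)c4ccc(F)cc4)c3)cc2N1c1ccc(F)cc1`. In a functional assay on MCF7 cells (Homo sapiens) for antiproliferative activity, read by MTT assay, with a stated time of 72 h (on this read-out lower numbers stand for stronger inhibition and higher numbers for weaker inhibition), compound 1 gives 32600 nM. In this assay compound 2 gives 32600 nM. In this assay compound 3 gives 32100 nM. The three measured values lie within the usual scatter of one another, so no order among them is read here.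

Compound 2 and compound 1 differ in one place: fluoro in place of methyl on an aromatic carbon The resulting step is no change at the digits printed from compound 2 to compound 1 (within the scatter).

Compound 2 and compound 3 carry different cores under the same sulfonamide half; the difference between the two cores is not broken down here, and their values show only that both sit in the same range.

Compound 3 and compound 4 differ in the same way: fluoro in place of methyl on an aromatic carbon The place line reads word for word as for the pair compound 2 to compound 1, so this is the same change on a different core. Because the measured instance gave no change at the digits printed from compound 2 to compound 1 (within the scatter), the expected step from compound 3 to compound 4 is a 1.0-fold lower number from compound 3 to compound 4 (0.00 log units; within the scatter), also within scatter. For compound 4 the estimate in this assay is 32000 nM, expected to fall between 15000 nM and 68000 nM. This rests on one measured pair only; a second core could behave otherwise, so the estimate is held loosely.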

Compound 4, half-maximal inhibitory concentration: > 40000 nM
Compound 4: only a limit was reported; the forecaster's own chance of this, stated with the estimate: 15%; at least 1.2-fold (0.09 log units) between middle value and limit.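

The result for compound 4 in this assay is a limit of the assay and not a number: the limit of > 40000 nM in this assay, at which 1 of the 4 values shown sits. As far as these compounds go, with that limit, the change from 4-methylphenyl to 4-fluorophenyl gives an at least 1.2-fold higher number from compound 3 to compound 4 (0.09 log units; that floor lies within the scatter), which is a floor only, so the full size of this step stays unknown. The two pairs show neither that the change carries over unaltered from one core to the other nor that its outcome depends on the core, and they stand as follows: the same change on two cores in this assay, no change at the digits printed (within the scatter) from compound 2 to compound 1 and an at least 1.2-fold higher number (0.09 log units; that floor lies within the scatter) from compound 3 to compound 4; the limit leaves it open whether they differ.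

The compounds shown leave open how the series responds to other groups at this place on the pendant phenyl, such as an amine, a carboxylic acid or a methoxy group, as only methyl and fluoro are compared here. Also open, from the compounds shown here alone, is what a longer chain at this place would give in this assay, and whether any member of the series reaches a clearly lower number there.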